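Replacing an Amide Nitrogen Group with 1-Carboxyethyl

The source may hold more compounds than are shown below. What is called first, only, known or untested is meant among the compounds shown, and "the series" means these compounds.

Compound 1 `CCn1c(C(=O)NCCCO)ccc1C(CC)(CC)c1ccc(OCS(=O)(=O)c2ccccc2)c(C)c1` gives 11300 nM in a functional assay on PC-3 cells (Homo sapiens) for antiproliferative activity, read by MTT assay, with a stated time of 24 h; a higher number here means a weaker inhibitor, a lower number a stronger inhibitor
Compound 2 `CCn1c(C(=O)N[C@@H](CO)CCCO)ccc1C(CC)(CC)c1ccc(OCS(=O)(=O)c2ccccc2)c(C)c1` gives 13400 nM in this assay

Compound 2 stands level with compound 1 within the scatter, so neither can be ranked on these numbers. Compound 3 `CCn1c(C(=O)N[C@@H](C)C(=O)O)ccc1C(CC)(CC)c1ccc(OCS(=O)(=O)c2ccccc2)c(C)c1` has not yet been measured. It differs from compound 2 on the amide-type nitrogen, where 1-carboxyethyl enters in place of a group of 7 heavy atoms (5 carbon, 2 oxygen; no ring) as counted here: a group of 5 heavy atoms (3 carbon, 2 oxygen; no ring) in place of a group of 7 heavy atoms (5 carbon, 2 oxygen; no ring), on an amide-type nitrogen. Among the compounds with values here, only one measured step bears on this change, also made on an amide-type nitrogen: a 1.2-fold higher number from compound 1 to compound 2 (0.07 log units; within the scatter). Neither measured compound carries 1-carboxyethyl, so that step is only indirect guidance. No step beyond the scatter is therefore expected in this assay, though with wide uncertainty. The expected change is a 1.0-fold higher number from compound 2 to compound 3 (0.02 log units; within the scatter). For compound 3 the estimated value is 14000 nM with an expected range from 6000 nM to 32000 nM.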

Compound 3, half-maximal inhibitory concentration: 16800 nM
Compound 3: the middle estimate sits 1.2-fold (0.08 log units) below what was measured; low and high end bracket the measured number.
By their numbers in this assay, from the lowest: compounds 1, 2 and 3 (each within the scatter of the next).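

In this assay, 1-carboxyethyl on the amide-type nitrogen gives a 1.3-fold higher number from compound 2 to compound 3 (0.10 log units; within the scatter) and a 1.5-fold higher number from compound 1 to compound 3 (0.17 log units; within the scatter) as the two steps to the new compound. Until now this nitrogen had carried only the two hydroxyl-bearing chains, so the result extends the earlier picture to a group with a carbonyl and shows no step beyond the scatter for any of the three groups. No measured information accounts for this insensitivity to the change, and none bears on the result.

The compounds shown leave open whether an amine, an aromatic ring or a longer chain ending in a carboxylic acid on this nitrogen would move the number beyond the scatter. They also leave open how the opposite stereocentre of 1-carboxyethyl would compare.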